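Compound 4: isopropyl on the amide-type nitrogen

The source may report more compounds than this note shows. Statements on the series, on what has been measured and on what is new or still open speak of the compounds shown alone.

In a functional assay on HCT-116 cells (Homo sapiens) for antiproliferative activity, read by MTT assay, with a stated time of 72 h (a lower number here means a stronger inhibitor, a higher number a weaker inhibitor), compound 1 `COc1cccc(N2C(=O)COc3ccc(-c4cnc(Cl)c(NS(=O)(=O)c5ccc(F)cc5)c4)cc32)c1` gives > 40000 nM as a limit of the assay, not a number. Compound 2 `O=C1COc2ccc(-c3cnc(Cl)c(NS(=O)(=O)c4ccc(F)cc4)c3)cc2N1C1CCCCC1` likewise gives > 40000 nM as a limit. For the measured compounds named here, compound 3 `COc1ccc(N2C(=O)COc3ccc(-c4cnc(Cl)c(NS(=O)(=O)c5ccc(F)cc5)c4)cc32)cc1` gives 30100 nM as the only actual number in the set. The remaining readings are described by the limit of > 40000 nM in this assay, at which 2 of the 3 values shown sit, and carry no exact size.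

Compound 4 `CC(C)N1C(=O)COc2ccc(-c3cnc(Cl)c(NS(=O)(=O)c4ccc(F)cc4)c3)cc21` differs from compound 3 at one place: isopropyl in place of 4-methoxyphenyl on an amide-type nitrogen in a ring with isopropyl in place of 4-methoxyphenyl on an amide-type nitrogen in a ring.

Going by the values given here, two measured steps bear on this place. The first is an at least 1.3-fold lower number from compound 1 to compound 3 (0.12 log units; that floor lies within the scatter) and the second is an at least 1.3-fold lower number from compound 2 to compound 3 (0.12 log units; that floor lies within the scatter) as a floor of the same size, so neither establishes a step beyond the scatter. Compound 2 has cyclohexyl, the closest measured match to isopropyl as a group without an aromatic ring, and its reading remains > 40000 nM as a limit.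

No clear step beyond the scatter is therefore expected in this assay and any expected drift is towards a higher number. The expected change is a 1.3-fold higher number from compound 3 to compound 4 (0.12 log units; within the scatter) and a reading at the limit is quite possible. For compound 4 the estimate is 40000 nM with an expected range of 15000 nM to 80000 nM in this assay.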

Compound 4, half-maximal inhibitory concentration: 18900 nM
Beside the measured number, compound 4's estimate is 2.1-fold (0.33 log units) above it, within the range that was stated.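

In the series, the isopropyl group carries no ring, yet in this assay (this assay) it stands on the amide-type nitrogen in place of 4-methoxyphenyl with a step inside the scatter (a 1.6-fold lower number from compound 3 to compound 4 (0.20 log units; within the scatter)), so an aromatic ring at this place is not required for a number short of the limit. This position also gives its first readable steps beyond the scatter, one for isopropyl in place of cyclohexyl (an at least 2.1-fold lower number from compound 2 to compound 4 (0.32 log units; beyond the scatter)) and one for isopropyl in place of 3-methoxyphenyl (an at least 2.1-fold lower number from compound 1 to compound 4 (0.32 log units; beyond the scatter)), so the two groups without an aromatic ring do not read alike. Both steps are floors and not full sizes, because the readings they start from are limits: (the limit of > 40000 nM in this assay, at which 2 of the 4 values shown sit).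

As far as these compounds go, whether methyl, or a longer chain ending in an amine or a carboxylic acid, on this nitrogen would move the number beyond the scatter from that of compound 4 stays open. Also open, from the compounds shown here alone, is how far compound 1 and compound 2 really lie from compound 4, and whether 3-methoxyphenyl and 4-methoxyphenyl truly differ at this place.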